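The compounds below may be only part of what the source reports. "The series", "measured", "known", "first", "only" and "open" are said of these compounds alone.

Measured so far:
Compound 1 `CCCC(=O)NCCCc1cc(OC)ccc1F` gives 100%.
Compound 2 `CCC(=O)NCCCc1ccc(F)c(OC)c1` gives 89%.

Both values come from an assay on isolated protein for agonist activity at melatonin receptor type 1C (Xenopus laevis), read by spectrophotometry (on this read-out lower numbers stand for smaller maximal responses and higher numbers for larger maximal responses), and on it compound 2 stands lowest of the two numbers; its nearest neighbour is compound 1, whose number lies higher by a gap beyond the usual scatter of repeated measurements.

The next compound, compound 3 `CCCC(=O)NCCCc1ccc(F)c(OC)c1`, keeps the whole of compound 2 except for one change: methyl in place of hydrogen on a saturated chain carbon, two bonds along the chain from a carbonyl carbon. The amide chain thus grows by a single carbon, so that the propanoyl group of compound 2 becomes a propylcarbonyl group in compound 3. Among the compounds with values here, no measured pair shows this exact step on its own, so its size is not known from the data.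

Still, a small rise seems the more likely outcome, because 100% is what compound 1, which also carries a propylcarbonyl group, reaches in this assay. Compound 3 is therefore expected to sit a little above compound 2, a step of about a number 6 percentage points higher from compound 2 to compound 3 (within the scatter). For compound 3 the estimated value is 95%, with a plausible range from 84% to 106%.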

Compound 3, largest response reached (reported as efficacy), in percent of the reference or control that the assay uses: 89%
Compound 3: the middle estimate sits 6 percentage points above what was measured, and the stated range covers the measured number.
By their numbers in this assay, from the lowest: compounds 2 and 3 (each within the scatter of the next); then compound 1.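

Methyl in place of hydrogen on a saturated chain carbon, two bonds along the chain from a carbonyl carbon, turns propanoyl into propylcarbonyl, and in this assay this change gives no change at the digits printed from compound 2 to compound 3 (within the scatter) as the first step in the series that can be read at a single place. At this position, then, one added carbon leaves the maximal response indistinguishable from that of the shorter chain, although this rests on a single pair of compounds on a single read-out. Nothing shown here offers an explanation for this result.

The compounds shown leave open what other groups at this end of the amide would do, such as a shorter acetyl group, a longer butylcarbonyl chain or a ring such as cyclopropylcarbonyl, so it remains unknown how far the chain can change before the response moves beyond the scatter. Compound 1 differs from compound 3 on the shared core as well, so it cannot show whether the same chain change would behave alike with the fluorine and methoxy groups placed as they are in compound 1.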